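Methoxy to methylsulfanyl on the thiophene-bearing nucleoside

The source may report more compounds than this note shows. Statements on the series, on what has been measured and on what is new or still open speak of the compounds shown alone.

Compound 2 `COc1ncnc2c1c(-c1ccsc1)cn2[C@@H]1O[C@H](CO)[C@@H](O)[C@H]1O` gives the lowest of the three numbers in a functional assay on HL-60 cells (Homo sapiens) for antiproliferative activity, read by XTT assay, with a stated time of 72 h (on this read-out higher numbers stand for weaker inhibition and lower numbers for stronger inhibition), at 130 nM. Compound 3 `COc1ncnc2c1c(-c1ccoc1)cn2[C@@H]1O[C@H](CO)[C@@H](O)[C@H]1O` gives 150 nM, and the step of a 1.2-fold higher number from compound 2 to compound 3 (0.06 log units; within the scatter) is within the scatter, so no order between the two is claimed. Compound 1 `COc1ncnc2c1c(I)cn2[C@@H]1O[C@H](CO)[C@@H](O)[C@H]1O` gives 2300 nM; the steps of an 18-fold lower number from compound 1 to compound 2 (1.25 log units; beyond the scatter) and a 15-fold lower number from compound 1 to compound 3 (1.19 log units; beyond the scatter) are the only large ones in the set. Compound 4 `CSc1ncnc2c1c(-c1ccsc1)cn2[C@@H]1O[C@H](CO)[C@@H](O)[C@H]1O` differs from compound 2 by methylsulfanyl in place of methoxy on an aromatic carbon. Among the measured compounds shown here, no measured step touches this part of the shared core; the large steps concern a different place, and the one exchange of thiophen-3-yl for furan-3-yl, a 1.2-fold higher number from compound 2 to compound 3 (0.06 log units; within the scatter), stayed within the scatter. Compound 4 is therefore expected to show a step of a 1.1-fold higher number from compound 2 to compound 4 (0.03 log units; within the scatter), within the scatter. For compound 4 the estimate is 140 nM, with a range from 50 nM to 400 nM.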

Compound 4, half-maximal inhibitory concentration: 4590 nM
For compound 4 the middle estimate is 33-fold (1.52 log units) below the measured one; measured number outside the range, above it.
By their numbers in this assay, from the lowest: compounds 2 and 3 (each within the scatter of the next); then compounds 1 and 4 (each within the scatter of the next).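

Methylsulfanyl in place of methoxy on the aromatic carbon next to the ring nitrogen gives a 35-fold higher number from compound 2 to compound 4 (1.55 log units; beyond the scatter) in this assay, the first large step at this position of the shared core. The two groups count the same in heavy atoms, donors and acceptors, so those counts do not separate them. No measured evidence accounts for this step.

Open, as far as these compounds go, is whether any replacement of methoxy has this effect, or methylsulfanyl alone; an amine or an ethoxy group here would bear on that. Also open, from the compounds shown here alone, is whether compound 3 responds in the same way to methylsulfanyl.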